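This account rests on a few compounds, and the source may have more. Where it says the series, first, only, none or still open, it means among the compounds named here.

Compound 1 `NC(=O)c1c(NC(=O)c2ccc(C(F)(F)F)cc2)sc2c1CCN(Cc1c(Cl)cccc1Cl)C2` and compound 2 `Cc1ccc(C(=O)Nc2sc3c(c2C(N)=O)CCN(Cc2c(Cl)cccc2Cl)C3)cc1` share one core and differ in a single group on the outer aromatic ring: methyl in place of trifluoromethyl on an aromatic carbon. In a functional assay on MKN-74 cells (Homo sapiens) for antiproliferative activity, with a stated time of 24 h (on this read-out lower numbers stand for stronger inhibition and higher numbers for weaker inhibition), compound 1 gives 8530 nM, and compound 2 gives 12300 nM. That change brought a 1.4-fold higher number from compound 1 to compound 2 (0.16 log units; within the scatter). Compound 3 `NC(=O)c1c(NC(=O)c2ccccc2C(F)(F)F)sc2c1CCN(C(=S)Nc1ccccc1Cl)C2` rests on a different core; how the two cores differ is not broken down here. In this assay compound 3 gives 21900 nM. Compound 4 `Cc1ccccc1C(=O)Nc1sc2c(c1C(N)=O)CCN(C(=S)Nc1ccccc1Cl)C2` is not yet measured and differs from compound 3 by methyl in place of trifluoromethyl on an aromatic carbon, the same kind of change as before, though here the group sits ortho to a large group rather than para to it. The earlier step of a 1.4-fold higher number from compound 1 to compound 2 (0.16 log units; within the scatter) stayed within the scatter. Resting on that, a step of a 1.4-fold higher number from compound 3 to compound 4 (0.14 log units; within the scatter) is expected. Compound 4 is estimated at 30000 nM, most likely between 12000 nM and 65000 nM.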

Compound 4, half-maximal inhibitory concentration: 11000 nM
The estimate for compound 4 lay 2.7-fold (0.44 log units) above the measured number, outside the stated range (below it).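

On the core of compound 3, the change from 2-(trifluoromethyl)phenyl to 2-methylphenyl gives a 2.0-fold lower number from compound 3 to compound 4 (0.30 log units; within the scatter), so this step alone is small in this assay. Set beside the earlier step, however, the change does not carry over from one core to the other as a single fixed step: the same change on two cores in this assay, a 1.4-fold higher number (0.16 log units; within the scatter) from compound 1 to compound 2 and a 2.0-fold lower number (0.30 log units; within the scatter) from compound 3 to compound 4, 2.9-fold (0.46 log units) apart, beyond the scatter of two such steps. Among the compounds shown here, this does not show what sets the two steps apart: the pairs differ both in their core and in where the group sits on the ring, and only two pairs are available.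

The compounds shown leave open whether the same change at the same ring position would give matching steps on both cores. They also leave open how an amine or a methoxy group in place of trifluoromethyl would read in this assay.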